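The source may hold more compounds than are shown below. What is called first, only, known or untested is meant among the compounds shown, and "the series" means these compounds.

Series notes. In a functional assay on OVCAR-5 cells (Homo sapiens) for inhibition, read by sulforhodamine B assay, with a stated time of 48 h, tested at 100 uM (a higher number here means a weaker effect of the compound at the concentration tested, a lower number a stronger effect), compound 1 `O=C(Nc1cccc(-n2cc(-c3ccncc3)c(-c3cc(O)cc(Cl)c3)n2)c1)Nc1ccc(Cl)c(C(F)(F)F)c1` gives -55%, compound 2 `O=C(Nc1cccc(-n2cc(-c3ccncc3)c(-c3cc(O)cc(Cl)c3)n2)c1)Nc1ccc(Cl)c(Cl)c1` gives -80%, and compound 3 `COc1cc(Cl)cc(-c2nn(-c3cccc(NC(=O)Nc4ccc(Cl)c(C(F)(F)F)c4)c3)cc2-c2ccncc2)c1` gives -89%. On the numbers shown, compound 3 sits at the low end: compound 2 lies within the scatter of it, while compound 1 lies beyond it, the step being a number 34 percentage points lower from compound 1 to compound 3 (beyond the scatter). Compound 4 `COc1cc(Cl)cc(-c2nn(-c3cccc(NC(=O)Nc4ccc(Cl)c(Cl)c4)c3)cc2-c2ccncc2)c1` differs from compound 3 by chloro in place of trifluoromethyl on an aromatic carbon. Going by the values given here, the one measured step of the same kind is a number 25 percentage points lower from compound 1 to compound 2 (beyond the scatter), and it bears directly on this change. A shift in that direction is therefore expected in this assay, but compound 3 already sits near the bottom of the range observed, so only a small step is expected, a number 6 percentage points lower from compound 3 to compound 4 (within the scatter). For compound 4 the estimated value is -95%, with an expected range from -105% to -80%.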

Compound 4, a percentage reported as activity, at one concentration (the size of the read-out at that concentration, not a potency): 9%
Beside the measured number, compound 4's estimate is 104 percentage points below it, and the stated range ends below it.
By their numbers in this assay, from the lowest: compounds 3 and 2 (each within the scatter of the next); then compound 1; then compound 4.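

In this assay, chloro in place of trifluoromethyl on an aromatic carbon has no single direction across the series, since on the methylated core it gives a number 98 percentage points higher from compound 3 to compound 4 (beyond the scatter): the same change on two cores in this assay, a number 25 percentage points lower (beyond the scatter) from compound 1 to compound 2 and a number 98 percentage points higher (beyond the scatter) from compound 3 to compound 4, 123 percentage points apart, beyond the scatter of two such steps. Methyl in place of hydrogen on the oxygen likewise reverses when the 3,4-dichlorophenyl group is present, giving a number 89 percentage points higher from compound 2 to compound 4 (beyond the scatter): the same change on two cores in this assay, a number 34 percentage points lower (beyond the scatter) from compound 1 to compound 3 and a number 89 percentage points higher (beyond the scatter) from compound 2 to compound 4, 123 percentage points apart, beyond the scatter of two such steps. Among these four compounds, the two changes do not add, and the outcome of each depends on the other.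

Going by these compounds, it remains open whether a bromo or a methyl at this position would behave like chloro or like trifluoromethyl. On these data alone, it also remains open whether an ethyl in place of methyl on the oxygen would show the same reversal.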